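A few compounds are considered here, and "the series" means these few. Any claim that something is new, unique, unknown or untested is made for them only; others in the source may bear on it.

The series shares one core, seen in compound 1 `COc1cc(Cl)cc(-c2nn(-c3cccc(NC(=O)Nc4cc(C(F)(F)F)cc(C(F)(F)F)c4)c3)cc2-c2ccncc2)c1` and compound 2 `COc1cc(Cl)cc(-c2nn(-c3cccc(NC(=O)Nc4ccc(Cl)c(Cl)c4)c3)cc2-c2ccncc2)c1`, and differs in the group carried on the amide-type nitrogen of the urea. In a functional assay on M14 cells (Homo sapiens) for inhibition, read by sulforhodamine B assay, with a stated time of 48 h, tested at 100 uM (a higher number here means a weaker effect of the compound at the concentration tested, a lower number a stronger effect), compound 1 gives -82%, while compound 2 gives -36%. Compound 2 thus stands highest of the two numbers, and its nearest neighbour, compound 1, lies a distance below it that exceeds the usual scatter. Compound 3 `COc1cc(Cl)cc(-c2nn(-c3cccc(NC(=O)Nc4cccc(C(F)(F)F)c4)c3)cc2-c2ccncc2)c1` has not been measured in this assay. It differs from compound 2 in one place: 3-(trifluoromethyl)phenyl in place of 3,4-dichlorophenyl on an amide-type nitrogen. Since compound 1, carrying two trifluoromethyl groups, gives -82%, a single trifluoromethyl is expected to move the number downward from compound 2 by a moderate step, estimated as a number 22 percentage points lower from compound 2 to compound 3 (beyond the scatter). Compound 3 is therefore expected to give about -58% in this assay, with a likely range from -90% to -20%.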

Compound 3, a percentage reported as activity, at one concentration (the size of the read-out at that concentration, not a potency): -78%
Compound 3: middle estimate off by 20 percentage points, on the high side, and the stated range covers the measured number.
By their numbers in this assay, from the lowest: compounds 1 and 3 (each within the scatter of the next); then compound 2.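

In this assay the change from 3,4-dichlorophenyl to 3-(trifluoromethyl)phenyl on the amide-type nitrogen gives a number 42 percentage points lower from compound 2 to compound 3 (beyond the scatter) and so shows that a ring with a single trifluoromethyl is enough for a large step at this position. Hydrogen in place of trifluoromethyl on an aromatic carbon gives a number 4 percentage points higher from compound 1 to compound 3 (within the scatter) in this assay and so shows that, among these compounds, the second trifluoromethyl brings no change that can be told apart from the scatter. Nothing available here explains either step.

On these data alone, it remains open whether a single chlorine, a methoxy group or a nitrile on this phenyl ring would read like the trifluoromethyl or like the 3,4-dichlorophenyl. Also open, as far as these compounds go, is how an unsubstituted phenyl or a saturated ring such as cyclohexyl on the same nitrogen would read.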